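Bromo to fluoro in a cytotoxicity series

The source may report more compounds than this note shows. Statements on the series, on what has been measured and on what is new or still open speak of the compounds shown alone.

Compound 1 `O=S(=O)(c1ccccc1)c1nc2ccccc2nc1N1CCc2ccccc2C1`: 19800 nM
Compound 2 `O=S(=O)(c1ccc(Br)cc1)c1nc2ccccc2nc1N1CCc2ccccc2C1`: > 50000 nM

In a functional assay on A549 cells (Homo sapiens) for cytotoxicity, read by MTT assay, with a stated time of 72 h (on this read-out lower numbers stand for stronger inhibition and higher numbers for weaker inhibition), compound 2 has only a limit, > 50000 nM, and no number.

Compound 3 `O=S(=O)(c1ccc(F)cc1)c1nc2ccccc2nc1N1CCc2ccccc2C1` carries fluoro in place of bromo on an aromatic carbon, para to a large group: fluoro in place of bromo on an aromatic carbon. For the measured compounds named here, the one measured step bearing on this change is an at least 2.5-fold higher number from compound 1 to compound 2 (0.40 log units; beyond the scatter), with bromo in place of hydrogen. Going by the values given here, no measured step involves fluoro, so the expectation is that compound 3 lies nearer compound 1 at 19800 nM. The expected step is an at least 2.0-fold lower number from compound 2 to compound 3 (0.30 log units; that floor lies within the scatter), towards a lower number. For compound 3 the estimated value in this assay is 25000 nM, with an expected range of 11000 nM to 50000 nM.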

Compound 3, half-maximal inhibitory concentration: 22900 nM
For compound 3 the middle estimate is 1.1-fold (0.04 log units) above the measured one; the measured number falls inside the stated range.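

In this assay, exchanging bromo for fluoro gives an at least 2.1-fold lower number from compound 2 to compound 3 (0.33 log units; beyond the scatter), so the rise seen with bromo does not extend to both halogens at this place. Fluoro in place of hydrogen gives a 1.2-fold higher number from compound 1 to compound 3 (0.06 log units; within the scatter), which leaves compound 3 and compound 1 indistinguishable on this read-out. The first step is only a floor, because compound 2 stands at a limit of the assay: the limit of > 50000 nM in this assay, at which 1 of the 3 values shown sits.

Still open, from the compounds shown here alone, is whether chloro, methoxy or an amine at this place would behave like fluoro or like bromo, and whether any group here would bring the number clearly below that of compound 1.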